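A Swap That Did Little, Tested on a Core with a Lower Number

A few compounds are considered here, and "the series" means these few. Any claim that something is new, unique, unknown or untested is made for them only; others in the source may bear on it.

Measured so far:
In a functional assay on DU-145 cells (Homo sapiens) for cytotoxicity, read by sulforhodamine B assay, with a stated time of 2 days, tested at 100 uM (a higher number here means more inhibition at the concentration tested (going by the name of the read-out), a lower number less inhibition), compound 1 `O=C(Nn1c(-c2cccc([N+](=O)[O-])c2)nc2c(-c3ccc(Cl)cc3)n[nH]c2c1=O)c1ccccc1` gives 94.3%.
In this assay compound 2 `COc1cccc(-c2nc3c(-c4ccc(Cl)cc4)n[nH]c3c(=O)n2NC(=O)c2ccccc2)c1` gives 94.1%.
In this assay compound 3 `O=C(Nn1c(-c2cccc([N+](=O)[O-])c2)nc2c(-c3ccco3)n[nH]c2c1=O)c1ccccc1` gives 16.1%.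

Compound 2 differs from compound 1 by methoxy in place of nitro on an aromatic carbon, and that change made a step of a number 0.2 percentage points lower from compound 1 to compound 2 (within the scatter). Compound 3 differs from compound 1 in its core, by furan-2-yl in place of 4-chlorophenyl on an aromatic carbon, a step of a number 78.2 percentage points lower from compound 1 to compound 3 (beyond the scatter). Compound 4 `COc1cccc(-c2nc3c(-c4ccco4)n[nH]c3c(=O)n2NC(=O)c2ccccc2)c1` has not yet been measured; it carries the same change, (methoxy in place of nitro on an aromatic carbon), on the core of compound 3, and the place of the change reads the same in both pairs. Because the earlier step was a number 0.2 percentage points lower from compound 1 to compound 2 (within the scatter), a step of about the same size is expected here: a number 0.9 percentage points higher from compound 3 to compound 4 (within the scatter). Compound 4 is therefore estimated to give 17% in this assay, between 5% and 35%.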

Compound 4, a percentage reported as inhibition, at one concentration (the size of the read-out at that concentration, not a potency): 50.5%
Estimate against measurement, compound 4: 33.5 percentage points below, and the stated range ends below it.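

In this assay, methoxy in place of nitro made a step of a number 34.4 percentage points higher from compound 3 to compound 4 (beyond the scatter), so a swap that did little on the core of compound 1 did not stay small on the core of compound 3: the same change on two cores in this assay, a number 0.2 percentage points lower (within the scatter) from compound 1 to compound 2 and a number 34.4 percentage points higher (beyond the scatter) from compound 3 to compound 4, 34.6 percentage points apart, beyond the scatter of two such steps. Read the other way, furan-2-yl in place of 4-chlorophenyl again lowered the number, with a step of a number 43.6 percentage points lower from compound 2 to compound 4 (beyond the scatter), but the size of that step also depended on the other group present: the same change on two cores in this assay, a number 78.2 percentage points lower (beyond the scatter) from compound 1 to compound 3 and a number 43.6 percentage points lower (beyond the scatter) from compound 2 to compound 4, 34.6 percentage points apart, beyond the scatter of two such steps. The two changes therefore do not simply add up in these four compounds, although one pair on each core cannot show why or predict what other groups would do.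

The compounds shown leave open how an amine or a carboxylic acid in place of nitro would behave on either core. They also leave open whether a thiophene or a plain phenyl in place of furan-2-yl would give a similar dependence on the other group.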